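A few compounds are considered here, and "the series" means these few. Any claim that something is new, unique, unknown or untested is made for them only; others in the source may bear on it.

In an ADME assay on HepG2 2.2.15 cells (Homo sapiens) for cytotoxicity (on this read-out higher numbers stand for lower toxicity in this test and lower numbers for higher toxicity in this test), the study offers two measured points and one open question. Compound 1 `O=C(Nc1ncc(Cc2ccc(Cl)cc2)s1)c1cccs1` is reported only at a limit of the test rather than as a number: in this assay compound 1 gives > 50000 nM, which is a limit, matching (the limit of > 50000 nM in this assay, at which 1 of the 2 values shown sits). Compound 2 `O=C(Nc1ncc(C(Oc2ccc3cc(Br)ccc3c2)c2ccc(Cl)cc2)s1)C1CC1` carries no number at all; in this assay compound 2 is recorded as "not toxic" (no number reported). Among the measured compounds shown here, no measured step connects these two compounds, so their values show only that neither reached a measurable toxicity.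

Compound 3 `O=C(Nc1ncc(C(Oc2ccc3cc(Br)ccc3c2)c2ccc(Cl)cc2)s1)c1cc(F)c(F)cc1F` differs from compound 2 by 2,4,5-trifluorophenyl in place of cyclopropyl on a carbonyl carbon. Since both measured compounds sit beyond what this assay resolves, the step from compound 2 to compound 3 is expected to change nothing beyond the scatter, with the result most likely again a limit. For compound 3 in this assay a value of 50000 nM is estimated, with a range from 20000 nM to 100000 nM.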

Compound 3, half-maximal cytotoxic concentration: "not toxic" (no number reported)
No number was reported for compound 3, and the estimate cannot be compared.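

Among the compounds shown here, compound 2 and compound 3 both carry no number in this assay, and no step between them can be read. The compounds shown leave open at what concentration, if any, toxicity would appear, and whether the group on the carbonyl carbon bears on it.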